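Three silent compounds and a chloro-for-methoxy swap

A few compounds are considered here, and "the series" means these few. Any claim that something is new, unique, unknown or untested is made for them only; others in the source may bear on it.

Compound 1 `COc1cccc(Cc2cc(C3CCCCC3)nn(CC(=O)Nc3ccc(Br)cc3)c2=O)c1`; in an assay on HL-60 cells for agonist activity at N-formyl peptide receptor 3 (Homo sapiens), read by calcium flux (on this read-out higher numbers stand for an effect only at larger amounts of compound and lower numbers for an effect already at smaller amounts), compound 1 gives > 50000 nM, a limit of the assay.
Compound 2 `COc1ccc(Cc2cc(-c3cccs3)nn(CC(=O)Nc3ccc(Br)cc3)c2=O)cc1`; compound 2 gives > 50000 nM, again only a limit.
Compound 3 `COc1ccc(Cc2cc(-c3ccc(OC)cc3)nn(CC(=O)Nc3ccc(Br)cc3)c2=O)cc1`; compound 3 gives > 50000 nM, also a limit.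

Going by the values given here, compound 3 thus stands at the limit of > 50000 nM in this assay, at which 3 of the 3 values shown sit, where every value so far sits. Compound 4 `COc1ccc(Cc2cc(-c3ccc(Cl)cc3)nn(CC(=O)Nc3ccc(Br)cc3)c2=O)cc1` differs from compound 3 by chloro in place of methoxy on an aromatic carbon. Among the compounds with values here, only one measured step touches this part of the shared core: a step that the two limits leave unreadable from compound 2 to compound 3, and its size is unreadable between two limits. Within the data shown here, no measured step gives a direction, so the expected step that the limit leaves unreadable from compound 3 to compound 4 is an estimate resting on three limits alone. Compound 4 is expected to give 60000 nM, in the range 15000 nM to 250000 nM, most likely reported again as a limit.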

Compound 4, half-maximal effective concentration: > 50000 nM
Compound 4 gave a limit, no number; the forecaster's own chance of this, stated with the estimate: 85%; the middle value is on the limit's open side.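

Compound 2, compound 3 and compound 4 all sit at a limit in this assay, so no step among them can be read: the limit of > 50000 nM in this assay, at which 4 of the 4 values shown sit.

From the compounds shown here alone, whether any change to the shared core gives a measurable value stays open.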